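Compound 3 after the limited propyl ester

A few compounds are considered here, and "the series" means these few. Any claim that something is new, unique, unknown or untested is made for them only; others in the source may bear on it.

Compound 1 `COC(=O)c1nc(C)c2c(c1N)C(=O)N(Cc1ccccc1)C2=O`: 7400 nM
Compound 2 `CCCOC(=O)c1nc(C)c2c(c1N)C(=O)N(Cc1ccccc1)C2=O`: < 5000 nM (a limit)

In a physicochemical assay for solubility, using the shake flask method, in simulated intestinal fluid, measured as kinetic solubility, with a stated time of 2 h, at 25 degrees C, at pH 6.5 (on this read-out higher numbers stand for higher solubility and lower numbers for lower solubility), compound 1 gives 7400 nM. Compound 2 has no exact number in this assay; its < 5000 nM is a limit.

Compound 3 `Cc1nc(C(=O)N(C)C)c(N)c2c1C(=O)N(Cc1ccccc1)C2=O` differs from compound 2 at one place: dimethylamino in place of propoxy on a carbonyl carbon. Propoxycarbonyl gives way to dimethylcarbamoyl.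

For the measured compounds named here, the one measured step at this carbonyl is an at least 1.4-fold lower number from compound 1 to compound 2 (0.17 log units; that floor lies within the scatter). Going by the values given here, it concerns the ester chain only, and no measured compound carries dimethylcarbamoyl, so it is a weak guide. Among the compounds with values here, the one exact number comes from compound 1 at 7400 nM, so compound 3 is expected to lie near it or somewhat higher.

The estimated change is an at least 2.4-fold higher number from compound 2 to compound 3 (0.38 log units; beyond the scatter), a modest rise with wide uncertainty. For compound 3 the estimate is 12000 nM, with an expected range of 5000 nM to 50000 nM.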

Compound 3, solubility: 172000 nM
Compound 3: middle estimate off by 14-fold (1.16 log units), on the low side; measured number outside the range, above it.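

In this assay the carbonyl carbon proves to be a place where the read-out can move a long way, which the change within the ester chain had not shown: dimethylamino in place of methoxy gives a 23-fold higher number from compound 1 to compound 3 (1.37 log units; beyond the scatter) on the otherwise shared core. Dimethylamino in place of propoxy gives an at least 34-fold higher number from compound 2 to compound 3 (1.53 log units; beyond the scatter) and points the same way. Compound 2 has only a limit, so this second step is a floor and not an exact size: the limit of < 5000 nM in this assay, at which 1 of the 3 values shown sits.

The compounds shown leave open whether this large step is particular to dimethylamino or would also appear with another amine on the same carbonyl carbon, such as pyrrolidine or a plain primary amide. They also leave open what a carboxylic acid at this place would give.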